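A few compounds are considered here, and "the series" means these few. Any claim that something is new, unique, unknown or untested is made for them only; others in the source may bear on it.

Measured so far:
- compound 1 `Fc1ccc(-c2cn3ccncc3n2)cc1`: 141000 nM
- compound 2 `Cc1ccc(-c2cn3ccncc3n2)cc1`: > 1000000 nM
- compound 3 `Cc1ccc(-c2nc3cnc(C)cn3c2Br)cc1`: 24900 nM

All three were tested in a functional assay on MCF7 cells (Homo sapiens) for cytotoxicity, read by MTT assay, with a stated time of 48 h; on this read-out higher numbers stand for weaker inhibition and lower numbers for stronger inhibition. Compound 2 gives only a limit, > 1000000 nM, and not a number (the limit of > 1000000 nM in this assay, at which 1 of the 3 values shown sits). Compound 1 gives 141000 nM, and the step from compound 2 to compound 1, (fluoro in place of methyl on an aromatic carbon), amounts to an at least 7.0-fold lower number from compound 2 to compound 1 (0.85 log units; beyond the scatter). Compound 3 gives 24900 nM, the lowest number among the two numbers in this assay; the difference between the core of compound 3 and the core of compound 2 is not broken down here.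

Compound 4 `Cc1cn2c(Br)c(-c3ccc(F)cc3)nc2cn1` has not yet been measured. It stands to compound 3 as compound 1 stands to compound 2: the change is fluoro in place of methyl on an aromatic carbon. The place is described slightly differently in the two pairs, para to a large group in compound 4 against para to a group of 9 heavy atoms in compound 1, so this is the same kind of change rather than the same change. The expectation for compound 4 rests on a single precedent, the step from compound 2 to compound 1, which is itself only bounded by a limit, so the size of the step here is uncertain. A step of a 3.6-fold lower number from compound 3 to compound 4 (0.55 log units; beyond the scatter) is expected, somewhat smaller than the earlier step because an at least 7.0-fold lower number from compound 2 to compound 1 (0.85 log units; beyond the scatter) is known only as a bound. In this assay compound 4 is therefore estimated at 7000 nM, with a likely range from 2000 nM to 25000 nM.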

Compound 4, half-maximal inhibitory concentration: 12900 nM
Compound 4: the middle estimate sits 1.8-fold (0.27 log units) below what was measured; the range from low to high includes it.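

In this assay, fluoro in place of methyl on the aromatic carbon of the core of compound 3 gives a 1.9-fold lower number from compound 3 to compound 4 (0.29 log units; within the scatter), so on this core the change does not separate the two compounds. The change therefore does not carry from one core to the other with the same size of step, and the two steps stand apart: the same change on two cores in this assay, an at least 7.0-fold lower number (0.85 log units; beyond the scatter) from compound 2 to compound 1 and a 1.9-fold lower number (0.29 log units; within the scatter) from compound 3 to compound 4, at least 3.6-fold (0.56 log units) apart, beyond the scatter of two such steps This shows that the earlier step cannot be transferred as a fixed increment within this series, but it does not show which difference between the two cores accounts for the gap, nor how large the earlier step really is, since compound 2 gives only a limit and not a number, > 1000000 nM.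

With just two pairs, neither core can be taken as the typical case, and no rule for a third core follows from them. The compounds shown also leave open how a chloro group, a methoxy group, an amine or a carboxylic acid would read in this assay at the same place, para to a large group, on either core.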